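Working notes on compounds 1 to 4

A few compounds are considered here, and "the series" means these few. Any claim that something is new, unique, unknown or untested is made for them only; others in the source may bear on it.

Measured so far in a functional assay on HeLa cells (Homo sapiens) for cytotoxicity, read by MTT assay, with a stated time of 48 h; on this read-out higher numbers stand for an effect only at larger amounts of compound and lower numbers for an effect already at smaller amounts:
compound 1 `CO[C@H]1O[C@H](COc2ccc(-c3ccccc3)cc2)[C@@H](O)[C@H](O)[C@H]1Oc1ccccc1` gives 33000 nM;
compound 2 `CO[C@H]1O[C@H](COc2ccccc2C(C)C)[C@@H](O)[C@H](O)[C@H]1Oc1ccc(OC2CCCCC2)cc1` gives 47000 nM;
compound 3 `CO[C@@H]1O[C@H](COc2ccccc2C(C)C)[C@@H](O)[C@H](O)[C@H]1Oc1ccc(OC2CCCCC2)cc1` gives 42000 nM.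

Compound 2 holds the highest of the three numbers, yet both other compounds sit within the scatter of it, so no order among them is claimed. Among the compounds with values here, the only single step measured, a 1.1-fold lower number from compound 2 to compound 3 (0.05 log units; within the scatter), rests on the fact that compounds 2 and 3 differ only in the configuration as drawn and says nothing about the aryl ether.

Compound 4 `CO[C@H]1O[C@H](COc2cccc(C(C)C)c2)[C@@H](O)[C@H](O)[C@H]1Oc1ccc(OC2CCCCC2)cc1` differs from compound 2 by 3-isopropylphenyl in place of 2-isopropylphenyl on an oxygen on a saturated carbon. Within the data shown here, no measured step moves an isopropyl group around its ring, so nothing bears directly on this change; all three numbers so far lie close together. No step beyond the scatter is expected in this assay. Compound 4 is estimated at 45000 nM, range 20000 nM to 100000 nM, which is expected to mean a 1.0-fold lower number from compound 2 to compound 4 (0.02 log units; within the scatter).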

Compound 4, half-maximal effective concentration: 28000 nM
The estimate for compound 4 lay 1.6-fold (0.21 log units) above the measured number; the range from low to high includes it.
By their numbers in this assay, from the lowest: compounds 4, 1, 3 and 2 (each within the scatter of the next).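

The isopropyl group on the aryl ether now has a measured step: 3-isopropylphenyl in place of 2-isopropylphenyl, on an oxygen on a saturated carbon, gives a 1.7-fold lower number from compound 2 to compound 4 (0.22 log units; within the scatter) in this assay. The earlier step changed only the configuration as drawn, whereas this one shows that moving the isopropyl group on this ring stays inside the scatter, so no order between the two isomers is claimed. Nothing at hand bears on this step.

Still open, as far as these compounds go, is whether an amine or a carboxylic acid in place of the isopropyl group would give a step beyond the scatter.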